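Pyridyl Swap on the Triazole, Starting From a Limit

The source may report more compounds than this note shows. Statements on the series, on what has been measured and on what is new or still open speak of the compounds shown alone.

Compound 3 `Cc1ccc(S(=O)(=O)Oc2ccc3c(c2C)[C@H](Cn2cc(-c4ccc(Cl)cc4)nn2)[C@@]24CC(=O)[C@@](C)(CC[C@@H]32)C4)cc1` stands at the edge of what a functional assay on HL-60 cells (Homo sapiens) for cytotoxicity, read by MTT assay, with a stated time of 4 days (a higher number here means a weaker inhibitor, a lower number a stronger inhibitor), can report: in this assay compound 3 gives > 20000 nM, which is a limit and not a number. Compound 1 `Cc1ccc(S(=O)(=O)Oc2ccc3c(c2C)[C@H](Cn2cc(-c4ccccc4)nn2)[C@@]24CC(=O)[C@@](C)(CC[C@@H]32)C4)cc1` also reaches only a limit in this assay, giving > 20000 nM. Compound 2 `Cc1c(O)ccc2c1[C@H](Cn1cc(-c3ccc(Cl)cc3)nn1)[C@@]13CC(=O)[C@@](C)(CC[C@@H]21)C3` likewise gives a limit of > 20000 nM in this assay. The step that the two limits leave unreadable from compound 1 to compound 3 and the step that the two limits leave unreadable from compound 2 to compound 3 cannot be sized because of the limit of > 20000 nM in this assay, at which 3 of the 3 values shown sit. Compound 4 `Cc1ccc(S(=O)(=O)Oc2ccc3c(c2C)[C@H](Cn2cc(-c4ccccn4)nn2)[C@@]24CC(=O)[C@@](C)(CC[C@@H]32)C4)cc1` differs from compound 3 by pyridin-2-yl in place of 4-chlorophenyl on an aromatic carbon. Within the data shown here, no measured step touches this exchange, and the two measured steps that end at compound 3 are both unreadable, so nothing among the measured compounds gives grounds to expect compound 4 to move away from the limit where compound 3 stands. The step that the limit leaves unreadable from compound 3 to compound 4 is therefore expected to be none beyond the scatter. Compound 4 is estimated at 30000 nM, within 15000 nM to 100000 nM, with a limit again the most likely report.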

Compound 4, half-maximal inhibitory concentration: > 20000 nM
Compound 4 ended at the assay's limit; the forecaster's own chance of this, stated with the estimate: 85%; the middle value lies beyond the limit too.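

Compound 4, like compound 1 and compound 3, reaches only a limit in this assay, so the steps from compound 1 and compound 3 to compound 4 cannot be read: the limit of > 20000 nM in this assay, at which 4 of the 4 values shown sit.

The compounds shown leave open whether any group at this place would give a readable number in this assay.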